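Trimming the tert-butyl in a sulfonylcarbamate series

The source may hold more compounds than are shown below. What is called first, only, known or untested is meant among the compounds shown, and "the series" means these compounds.

Compound 1 `CCCCOC(=O)NS(=O)(=O)c1ccc(CCC)cc1-c1ccc(Cn2c(C(C)(C)C)nc3ccccc32)cc1` gives the lower of the two measured numbers in an assay on membranes from HEK293 cells for displacement of a labelled ligand from Type-2 angiotensin II receptor (Homo sapiens), read by radioligand binding (a lower number here means a stronger inhibitor, a higher number a weaker inhibitor), namely 5.3 nM; compound 2 `CCCc1ccc(S(=O)(=O)NC(=O)OCCCC(F)(F)F)c(-c2cc(F)c(Cn3c(C(C)(C)C)nc4ccccc43)c(F)c2)c1` gives 12 nM in this assay, a gap that lies beyond the scatter. Compound 3 `CCCCOC(=O)NS(=O)(=O)c1ccc(CCC)cc1-c1ccc(Cn2c(C(C)C)nc3ccccc32)cc1` differs from compound 1 by hydrogen in place of methyl on a saturated chain carbon bound to an aromatic carbon and two saturated chain carbons. Among the measured compounds shown here, no pair of measured compounds shows this change, so its effect cannot be read from the numbers at hand. A modest loss of binding is expected, the step of a 2.8-fold higher number from compound 1 to compound 3 (0.45 log units; beyond the scatter) running toward a higher number, somewhat beyond the scatter. Compound 3 is estimated at 15 nM, within a range from 5 nM to 50 nM.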

Compound 3, inhibition constant: 4 nM
The estimate for compound 3 lay 3.8-fold (0.57 log units) above the measured number; the measured number lies below the stated range.
By their numbers in this assay, from the lowest: compounds 3 and 1 (each within the scatter of the next); then compound 2.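

Replacing tert-butyl with isopropyl gives a 1.3-fold lower number from compound 1 to compound 3 (0.12 log units; within the scatter) in this assay, so compound 1 and compound 3 cannot be told apart. One methyl can therefore leave this saturated chain carbon without a change in binding that exceeds the scatter, at least in the setting of compound 1. No measurement available here offers an explanation for this.

Going by these compounds, whether binding holds when this position carries an ethyl, a cyclopropyl or a carboxylic acid remains open. So does whether the same change would behave alike in compound 2.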